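Nitro in place of hydrogen on the phenyl of compound 2

This account rests on a few compounds, and the source may have more. Where it says the series, first, only, none or still open, it means among the compounds named here.

Compound 2 `O=C1NC(=O)/C(=C/c2ccc(OCCSc3nnc(-c4ccccc4)[nH]3)cc2)S1` in a functional assay on the whole organism (plasma, strain Wistar) with Rattus norvegicus as the target, with a stated time of 15 days, at a dose of 10 mg/kg by the oral route (a higher number here means a stronger effect of the compound at the dose given, a lower number a weaker effect), gives 10.6%, the lowest of the three numbers shown, though its distances to compound 1 `O=C1NC(=O)/C(=C/c2ccc(OCc3csc(-c4ccccc4)n3)cc2)S1`, which gives 20.4%, and to compound 3 `Cc1ccc(-c2nnc(SCCOc3ccc(/C=C4\SC(=O)NC4=O)cc3)[nH]2)cc1`, which gives 20.4%, both lie within the scatter. Compound 4 `O=C1NC(=O)/C(=C/c2ccc(OCCSc3nnc(-c4ccccc4[N+](=O)[O-])[nH]3)cc2)S1` differs from compound 2 by nitro in place of hydrogen on an aromatic carbon. For the measured compounds named here, the only measured step on the same phenyl is a number 9.8 percentage points higher from compound 2 to compound 3 (within the scatter), which stays within the scatter; no step with a nitro group exists. On that basis no change beyond the scatter is expected in this assay, so the step of a number 3.4 percentage points higher from compound 2 to compound 4 (within the scatter) is estimated to be small. Compound 4 is therefore expected to give 14%, within 2% to 28%.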

Compound 4, a percentage reported as activity, at one dose (the size of the read-out at that dose, not a potency): 15.3%
Compound 4: the middle estimate sits 1.3 percentage points below what was measured, within the range that was stated.
By their numbers in this assay, from the lowest: compounds 2, 4, 1 and 3 (each within the scatter of the next).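

In this assay, 2-nitrophenyl in place of phenyl gives a number 4.7 percentage points higher from compound 2 to compound 4 (within the scatter), so a nitro group on this aromatic carbon, ortho to a large group, brings no step beyond the scatter. Set against the 4-methylphenyl, the same group gives a number 5.1 percentage points lower from compound 3 to compound 4 (within the scatter), so the two substituted phenyls cannot be told apart here. Nothing available explains these small steps. Still open, on these data alone, is whether an amine or a carboxylic acid on this phenyl would give a step beyond the scatter. Also open, as far as these compounds go, is whether a nitro group elsewhere on the ring would read the same.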